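Swapping the biaryl end group in a cytotoxicity-silent amide series

The source may report more compounds than this note shows. Statements on the series, on what has been measured and on what is new or still open speak of the compounds shown alone.

Compound 1, `CC(C)N(Cc1cccc(OCCCCCC(=O)O)c1)C(=O)c1ccc(-c2cccc(OC(F)(F)F)c2)cc1`, gives > 26000 nM in an ADME assay on Raji cells (Homo sapiens) for cytotoxicity, read by CellTiter-Glo and resazurin assay, with a stated time of 72 h (a higher number here means that more compound is needed for the effect, a lower number that less compound is needed), a limit of the assay rather than a number.
Compound 2, `COc1cc(F)cc(-c2ccc(C(=O)N(Cc3cccc(OCCCCCC(=O)O)c3)C(C)C)cc2)c1`, gives > 26000 nM in this assay, again only a limit.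
Compound 3, `CCOC(=O)CCCCCOc1cccc(CN(C(=O)c2ccc(-c3cccc(OC(F)(F)F)c3)cc2)C(C)C)c1`, gives > 26000 nM in this assay, again only a limit.

Compound 4, `CCOC(=O)CCCCCOc1cccc(CN(C(=O)c2ccc(-c3cc(F)cc(OC)c3)cc2)C(C)C)c1`, has not yet been measured. It differs from compound 3 by 3-fluoro-5-methoxyphenyl in place of 3-(trifluoromethoxy)phenyl on an aromatic carbon. The same change, (3-fluoro-5-methoxyphenyl in place of 3-(trifluoromethoxy)phenyl on an aromatic carbon), separates compound 1 from compound 2, where it made a step that the two limits leave unreadable from compound 1 to compound 2. The two cores differ by ethyl in place of hydrogen on an oxygen next to a carbonyl group, a step that the two limits leave unreadable from compound 1 to compound 3. Going by the values given here, every value so far sits at the limit of > 26000 nM in this assay, at which 3 of the 3 values shown sit, so no shift in the read-out has ever been seen. Compound 4 is expected to show a step that the limit leaves unreadable from compound 3 to compound 4 in this assay because compound 1 and compound 2 both sit at the limit of > 26000 nM in this assay, at which 3 of the 3 values shown sit. Compound 4 is therefore estimated at 40000 nM, most likely reported again only as a limit.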

Compound 4, half-maximal effective concentration: > 26000 nM
Compound 4 was reported as a limit; the forecaster's own chance of this, stated with the estimate: 90%; the middle value is on the limit's open side.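

No step to compound 4 from compound 2 or compound 3 can be read, as all of these values are limits: the limit of > 26000 nM in this assay, at which 4 of the 4 values shown sit.

The compounds shown leave open what concentration of any of them would produce an effect in this assay.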